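Ethylsulfonyl to methylsulfonyl on the shared core

The compounds below may be only part of what the source reports. "The series", "measured", "known", "first", "only" and "open" are said of these compounds alone.

In an ADME assay on microsomes from liver (Mus musculus) for metabolic stability, read by LC-MS, using NADPH, with stated times of 10 min and 30 min (a higher number here means faster removal of the compound, a lower number slower removal), compound 1 (`CC[C@@H]1c2cc(Cl)ccc2C(=O)N1c1cncc2c1CCC[C@H]2NC(C)=O`) gives < 20.2 mL/min/kg, which is a limit of the assay and not a number. Compound 2 (`CCC(=O)N[C@@H]1CCCc2c1cncc2N1C(=O)c2ccc(Cl)cc2[C@@H]1CC`) also gives only a limit, < 20.2 mL/min/kg. For the measured compounds named here, compound 3 (`CCS(=O)(=O)N[C@@H]1CCCc2c1cncc2N1Cc2cc(Cl)ccc2C1=O`) gives 27 mL/min/kg, the only actual number so far. Compound 4 (`CS(=O)(=O)N[C@@H]1CCCc2c1cncc2N1Cc2cc(Cl)ccc2C1=O`) differs from compound 3 by hydrogen in place of methyl on a saturated chain carbon bound to a sulfonyl sulfur, turning ethylsulfonyl into methylsulfonyl. Going by the values given here, no measured pair isolates this change, so the expected 1.2-fold lower number from compound 3 to compound 4 (0.07 log units; within the scatter) in this assay is small, slightly downward and within the usual scatter. For compound 4 the estimated clearance is 23 mL/min/kg, with an expected range of 15 mL/min/kg to 36 mL/min/kg.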

Compound 4, clearance: < 20.2 mL/min/kg
Compound 4: only a limit was reported; the forecaster's own chance of this, stated with the estimate: 35%; middle value at least 1.1-fold (0.05 log units) away from the limit.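

For the compounds shown here, the change from ethylsulfonyl to methylsulfonyl gives the first readable step at this position in this assay: an at least 1.3-fold lower number from compound 3 to compound 4 (0.12 log units; that floor lies within the scatter). From the compounds shown here alone, compound 4 carries a limit of the assay and not a number, so the step is only a floor, and its true size remains unknown. Further differences in this range are hard to resolve with this read-out: the limit of < 20.2 mL/min/kg in this assay, at which 3 of the 4 values shown sit.

Going by these compounds, how far the clearance of compound 4 lies past the limit remains open. So does whether a longer chain such as propylsulfonyl, or an amine in place of the ethyl group, would shift the clearance of compound 3.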